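Restoring an aryl group on the urea nitrogen

The source may hold more compounds than are shown below. What is called first, only, known or untested is meant among the compounds shown, and "the series" means these compounds.

In a functional assay on T-24 cells (Homo sapiens) for antiproliferative activity, read by MTT assay, with a stated time of 48 h (a higher number here means a weaker inhibitor, a lower number a stronger inhibitor), compound 1 `O=C(Nc1cccc(CNc2nccnc2Cl)c1)Nc1ccccc1F` gives 7450 nM, and compound 3 `CC(C)(C)c1ccc(NC(=O)Nc2cccc(CNc3nccnc3Cl)c2)cc1` gives 6010 nM. Compound 2 `O=C(Nc1cccc(CNc2nccnc2Cl)c1)NC1CCCCC1` reaches only a limit of the assay, > 40000 nM. Among the three measured values compound 2 therefore stands at the weak end, sitting at the limit of > 40000 nM in this assay, at which 1 of the 3 values shown sits. The change now considered is 2-methylphenyl in place of cyclohexyl on an amide-type nitrogen, which gives compound 4 `Cc1ccccc1NC(=O)Nc1cccc(CNc2nccnc2Cl)c1`. Among the measured compounds shown here, the one measured step that bears on this runs in the opposite direction: an at least 5.3-fold higher number from compound 1 to compound 2 (0.72 log units; beyond the scatter). Putting an aromatic ring back on the amide-type nitrogen is expected to reverse that loss, so compound 4 is expected near 7000 nM, between 2500 nM and 20000 nM. The expected step is an at least 5.7-fold lower number from compound 2 to compound 4 (0.75 log units; beyond the scatter), a return toward the numbers of compound 1 and compound 3.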

Compound 4, half-maximal inhibitory concentration: 13600 nM
For compound 4 the middle estimate is 1.9-fold (0.29 log units) below the measured one; low and high end bracket the measured number.
By their numbers in this assay, from the lowest: compounds 3, 1 and 4 (each within the scatter of the next, the first and the last beyond it). At a limit, above all of these: compound 2.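

In this assay, 2-methylphenyl in place of cyclohexyl on the amide-type nitrogen gives an at least 2.9-fold lower number from compound 2 to compound 4 (0.46 log units; beyond the scatter), so the return from the limit is not tied to the 2-fluorophenyl of compound 1 alone. Going by these compounds, the size of that step stays open-ended, as one end of it is a limit: the limit of > 40000 nM in this assay, at which 1 of the 4 values shown sits. Methyl in place of fluoro on the aromatic carbon gives a 1.8-fold higher number from compound 1 to compound 4 (0.26 log units; within the scatter), so the two groups are not told apart here.

The compounds shown leave open how an unsubstituted phenyl would read on this nitrogen. They also leave open whether a benzyl group would behave like the aromatic rings or like cyclohexyl.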